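The source may report more compounds than this note shows. Statements on the series, on what has been measured and on what is new or still open speak of the compounds shown alone.

Measured compounds:
compound 1 `COc1ccc(Cn2nc(-c3ccccc3)c3cc(C(=N)Nc4ccccc4)ncc32)cc1` — in an ADME assay on AG1523 cells (Homo sapiens) for cytotoxicity, read by MTT assay, with a stated time of 72 h (a lower number here means a stronger inhibitor, a higher number a weaker inhibitor), compound 1 gives "not determined" (no result reported)
compound 2 `COc1ccc(Cn2nc(-c3ccccc3)c3cc(C(=N)Nc4ccccc4)nc(NC4CCCCC4)c32)cc1` — in this assay compound 2 gives 26800 nM
compound 3 `N=C(Nc1ccccc1)c1cc2c(-c3ccccc3)n[nH]c2cn1` — in this assay compound 3 gives "not determined" (no result reported)

Compound 1 stands without a number in this assay; compound 3 likewise carries none. Among the compounds with values here, the only number in the set belongs to compound 2, which shares the core of compound 1 and adds a cyclohexylamino group, and its value points to weak cytotoxicity. Within the data shown here, no pair of measured compounds differs in one place, so no step size is available to anchor a comparison.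

Compound 4 `COc1ccc(Cn2nc(-c3ccccc3)c3cc(C(=N)Nc4ccc(N5CCN(C)CC5)cc4)ncc32)cc1` is the unmeasured member. It differs from compound 1 as follows: 4-methylpiperazin-1-yl in place of hydrogen on an aromatic carbon. With compound 1 itself unnumbered, the expectation for compound 4 rests on compound 2 alone, whose value of 26800 nM suggests that this core is, at best, weakly cytotoxic. No shift in this assay beyond the usual scatter is expected from the added group, in either direction; a limit rather than a number is a real possibility. Compound 4 is therefore estimated at 30000 nM, with a plausible range of 8000 nM to 100000 nM.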

Compound 4, half-maximal inhibitory concentration: 10200 nM
Beside the measured number, compound 4's estimate is 2.9-fold (0.47 log units) above it; low and high end bracket the measured number.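

Within the data shown here, compound 4 yields no new step in this assay: compound 1, its one-place partner, carries no number there. Going by these compounds, what the 4-methylpiperazin-1-yl group does to cytotoxicity on the shared core stays open. No supporting data bear on this result.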